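Swapping Piperidine for Morpholine on a Chlorinated Chromone

A few compounds are considered here, and "the series" means these few. Any claim that something is new, unique, unknown or untested is made for them only; others in the source may bear on it.

Among the measured compounds shown here, compound 3 `O=c1c(Cl)c(CSC(=S)N2CCCCC2)oc2ccccc12` is the only compound with an actual number in a functional assay on MDA-MB-435S cells (Homo sapiens) for antiproliferative activity, read by MTT assay, with a stated time of 72 h (on this read-out higher numbers stand for weaker inhibition and lower numbers for stronger inhibition), where compound 3 gives 770 nM. Compound 1 `O=c1cc(CSC(=S)N2CCCCC2)oc2ccccc12` reaches only the limit of the assay, giving > 25000 nM. Compound 2 `O=c1cc(CSC(=S)N2CCCC2)oc2cc(Cl)ccc12` likewise reaches only the limit, giving > 25000 nM. For the measured compounds named here, the one measured step, an at least 32-fold lower number from compound 1 to compound 3 (1.51 log units; beyond the scatter), is the sole comparison available, and its size rests on (the limit of > 25000 nM in this assay, at which 2 of the 3 values shown sit). Compound 4 `O=c1c(Cl)c(CSC(=S)N2CCOCC2)oc2ccccc12` differs from compound 3 by morpholin-4-yl in place of piperidin-1-yl on a thiocarbonyl carbon. Going by the values given here, no measured step touches this part of the molecule, so the chloro step offers no guide to it. Compound 4 is therefore expected to sit close to its parent, the expected step being a 1.6-fold higher number from compound 3 to compound 4 (0.19 log units; within the scatter), not beyond the scatter. The estimate for compound 4 is 1200 nM, within 400 nM to 4000 nM.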

Compound 4, half-maximal inhibitory concentration: 4100 nM
The estimate for compound 4 lay 3.4-fold (0.53 log units) below the measured number; measured number above the stated range.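

In this assay, the step of a 5.3-fold higher number from compound 3 to compound 4 (0.73 log units; beyond the scatter) shows that the ring on the thiocarbonyl carbon matters, a point the chloro step could not address. Exchanging one ring carbon of piperidin-1-yl for the oxygen of morpholin-4-yl is enough to weaken the inhibition, though compound 4 remains measurable. Nothing shown here explains why this step occurs.

Going by these compounds, what remains open is how other groups at this carbon would behave. A piperazin-1-yl ring or an open-chain diethylamino group might match compound 3, or fall further away.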